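A few compounds are considered here, and "the series" means these few. Any claim that something is new, unique, unknown or untested is made for them only; others in the source may bear on it.

Three compounds have been run in a functional assay on SW480 cells (Homo sapiens) for cytotoxicity, read by MTT assay, with a stated time of 24 h; a higher number here means a weaker inhibitor, a lower number a stronger inhibitor. Compound 1 `C=CC1=C(C(=O)NCCC)C(c2ccc(F)cc2)OC1` carries a propyl amide on the shared core. In this assay compound 1 gives only a limit, > 100000 nM. Compound 2 `C=CC1=C(C(=O)NCc2ccc(C)cc2)C(c2ccc(F)cc2)OC1` differs from compound 1 by 4-methylphenyl in place of ethyl on a saturated chain carbon bound to an amide-type nitrogen. In this assay compound 2 likewise gives only a limit, > 100000 nM. The step that the two limits leave unreadable from compound 1 to compound 2 therefore cannot be sized from these two values. Compound 3 `C=CC1=C(C(=O)NCCC)C(c2ccc(OC)c(OC)c2)OC1` has a different core; the difference between the cores of compound 1 and compound 3 is not broken down here. In this assay compound 3 also gives only a limit, > 100000 nM. Compound 4 `C=CC1=C(C(=O)NCc2ccc(C)cc2)C(c2ccc(OC)c(OC)c2)OC1` is not yet measured and differs from compound 3 by 4-methylphenyl in place of ethyl on a saturated chain carbon bound to an amide-type nitrogen, the same change as made from compound 1 to compound 2, at the same place. In this assay the expected step that the limit leaves unreadable from compound 3 to compound 4 rests on (the limit of > 100000 nM in this assay, at which 3 of the 3 values shown sit), which leaves no readable movement on either core. Compound 4 is expected at 150000 nM, most likely reported again as a limit, with a range from 50000 nM to 500000 nM.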

Compound 4, half-maximal inhibitory concentration: > 100000 nM
Compound 4 ended at the assay's limit; the forecaster's own chance of this, stated with the estimate: 85%; the middle value does not contradict the limit.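

In this assay compound 4 gives > 100000 nM as a limit of the assay and not a number. No new step can be read from compound 3 to compound 4: the limit of > 100000 nM in this assay, at which 4 of the 4 values shown sit.

The compounds shown leave open whether any amide group or core in this series reaches a readable value in this assay at all.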